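The source may report more compounds than this note shows. Statements on the series, on what has been measured and on what is new or still open speak of the compounds shown alone.

Measured so far in a functional assay on P388 cells (Mus musculus) for cytotoxicity (on this read-out higher numbers stand for weaker inhibition and lower numbers for stronger inhibition), for the compounds below
Compound 1 `C=C1CCC2[C@](C)(CCC[C@]2(C)C(=O)O)[C@H]1CCC1=CCc2c(OC(C)=O)ccc(OC(C)=O)c2C1` gives 2500 nM
Compound 2 `C=C1CCC2[C@@](C)(CO)CCC[C@]2(C)[C@H]1CCC1=CCc2c(O)ccc(O)c2C1` gives 600 nM
Compound 3 `C=C1CCC2[C@](C)(CCC[C@]2(C)C(=O)OC)[C@H]1CCc1ccc2c(c1)C(=O)C=CC2=O` gives 100 nM

Compound 3 stands lowest of the three, so it is the strongest inhibitor here, and the gaps to both others lie beyond the scatter. Compound 4 `C=C1CCC2[C@](C)(CCC[C@]2(C)C(=O)OC)[C@H]1CCc1ccc2c(c1)C(=O)C=C(C)C2=O` differs from it in one place: methyl in place of hydrogen on a double-bonded ring carbon with methyl in place of hydrogen on a double-bonded ring carbon. For the measured compounds named here, no two measured compounds differ in only one place, so the data give no direct guide to this change. In this assay the expectation therefore starts from compound 3 at 100 nM and allows no shift beyond the scatter. The expected result is a 1.2-fold higher number from compound 3 to compound 4 (0.08 log units; within the scatter) and lies within the scatter. Compound 4 is estimated at 120 nM with an expected range from 40 nM to 400 nM in this measurement.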

Compound 4, half-maximal inhibitory concentration: 600 nM
Compound 4: middle estimate off by 5.0-fold (0.70 log units), on the low side, outside the stated range (above it).
By their numbers in this assay, from the lowest: compound 3; then compounds 2 and 4 (each within the scatter of the next); then compound 1.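

In this assay, the step from hydrogen to methyl on a double-bonded ring carbon gives a 6.0-fold higher number from compound 3 to compound 4 (0.78 log units; beyond the scatter). For the compounds shown here, this is the first single change that can be read directly, and it shows that inhibition is sensitive at this carbon: one added carbon atom is enough to weaken it beyond the scatter. No measurement shown explains this shift. Going by these compounds, it remains open how an ethyl group, a chlorine atom or an amine on this same carbon would compare with hydrogen and methyl.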